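The source may hold more compounds than are shown below. What is called first, only, known or untested is meant among the compounds shown, and "the series" means these compounds.

In a functional assay on COLO 205 cells (Homo sapiens) for inhibition, read by sulforhodamine B assay (a higher number here means a weaker inhibitor of growth, a lower number a stronger inhibitor of growth), compound 1 (`c1ccc(-c2ccc(-c3ccc(-c4nc5ccccc5[nH]4)cc3)cc2)cc1`) gives 100000 nM and compound 2 (`Fc1ccc(-c2ccc(-c3ccc(-c4nc5ccccc5[nH]4)cc3)cc2)cc1`) gives 100000 nM, level at the digits shown and together the highest of the three numbers. Compound 3 (`COc1ccc(-c2ccc(-c3ccc(-c4nc5ccccc5[nH]4)cc3)cc2)cc1`) gives 45200 nM. Compound 4 (`Oc1cccc2[nH]c(-c3ccc(-c4ccc(-c5ccc(F)cc5)cc4)cc3)nc12`) has hydroxy in place of hydrogen on an aromatic carbon of compound 2: hydroxy in place of hydrogen on an aromatic carbon. Among the compounds with values here, no measured step changes this fused system, so the evidence is indirect. Fluoro for hydrogen gave no change at the digits printed from compound 1 to compound 2 (within the scatter), methoxy for hydrogen gave a 2.2-fold lower number from compound 1 to compound 3 (0.34 log units; beyond the scatter), and methoxy for fluoro gave a 2.2-fold lower number from compound 2 to compound 3 (0.34 log units; beyond the scatter). The expected change in this assay is modest and towards a lower number, an estimated 2.2-fold lower number from compound 2 to compound 4 (0.35 log units; beyond the scatter). For compound 4 the estimated value is 45000 nM, with an expected range of 12000 nM to 100000 nM.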

Compound 4, concentration for 50% growth inhibition: 1220 nM
Beside the measured number, compound 4's estimate is 37-fold (1.57 log units) above it, outside the stated range (below it).
By their numbers in this assay, from the lowest: compound 4; then compound 3; then compounds 1 and 2 (each within the scatter of the next).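

This is the first step shown on the fused system: in this assay, hydroxy on its six-membered aromatic ring of carbon only gives an 82-fold lower number from compound 2 to compound 4 (1.91 log units; beyond the scatter). That step is much larger than a 2.2-fold lower number from compound 1 to compound 3 (0.34 log units; beyond the scatter), so this position responds more strongly than any earlier change shows. Nothing shown here accounts for the size of the step.

Going by these compounds, it remains open whether the drop is specific to hydroxy, since methoxy or an amine at this same place would test that. Also open, on these data alone, is whether hydroxy elsewhere on this ring gives a similar number.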